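This account rests on a few compounds, and the source may have more. Where it says the series, first, only, none or still open, it means among the compounds named here.

Measured in a physicochemical assay for inhibition, read by spectrophotometry, with a stated time of 10 min; a higher number here means a weaker inhibitor, a lower number a stronger inhibitor:
- compound 1 `COc1ccc(CN(Cc2ccc(OC(F)(F)F)cc2)c2ccc3nc(N)nc(N)c3c2)cc1`: 24500 nM
- compound 2 `COc1ccc(CN(Cc2ccc(OC)cc2)c2ccc3nc(N)nc(N)c3c2)cc1`: 114000 nM

Of these two, compound 1 has the lower number and is the stronger inhibitor. The next compound to be tested is compound 3 `CCN(Cc1ccc(OC(F)(F)F)cc1)c1ccc2nc(N)nc(N)c2c1`, which is made from compound 1 by a larger change: methyl in place of 4-methoxyphenyl on a saturated chain carbon bound to a nitrogen on an aromatic ring. Put another way, 4-methoxybenzyl becomes ethyl.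

Within the data shown here, only one measured step exists for comparison: a 4.7-fold higher number from compound 1 to compound 2 (0.67 log units; beyond the scatter). That step alters the trifluoromethyl group, which compound 3 keeps, and not the group that compound 3 loses. It therefore shows only that a small edit elsewhere in this series can move the number by a modest amount. Among the measured compounds shown here, no measured compound shows what removing the 4-methoxyphenyl does, so even the direction is a judgement. A step of similar size toward a higher number, meaning a weaker inhibitor, seems most likely. The expected change is a 2.4-fold higher number from compound 1 to compound 3 (0.39 log units; beyond the scatter). For compound 3 the estimated value is 60000 nM, with an expected range from 15000 nM to 200000 nM.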

Compound 3, half-maximal inhibitory concentration: 7360 nM
Compound 3: middle estimate off by 8.2-fold (0.91 log units), on the high side, and the stated range ends above it.
By their numbers in this assay, from the lowest: compound 3; then compound 1; then compound 2.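

In this assay, the 4-methoxybenzyl group of compound 1 turns out not to be needed for inhibition: exchanging it for ethyl gives a 3.3-fold lower number from compound 1 to compound 3 (0.52 log units; beyond the scatter), a change beyond the usual scatter and toward a stronger inhibitor. Among these compounds, the earlier pair varied only the trifluoromethyl group, so this is the first reading at this position, and it shows that a much smaller group with no ring can stand here without any loss of inhibition. The information at hand offers no measurement that accounts for this improvement.

Ethyl is a single replacement, and this one step cannot separate the effect of removing the aromatic ring from that of removing its methoxy group; a plain benzyl group, a longer chain such as propyl or butyl, or a chain ending in an amine or a carboxylic acid would each probe a different part of that question. On these data alone, it also remains open whether exchanging 4-methoxybenzyl for ethyl would lower the number in the same way with methoxy in place of trifluoromethyl, as in compound 2.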